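The compounds below may be only part of what the source reports. "The series", "measured", "known", "first", "only" and "open" are said of these compounds alone.

Measured in a functional assay on HeLa cells (Homo sapiens) for cytotoxicity, read by resazurin assay, with a stated time of 72 h; on this read-out higher numbers stand for weaker inhibition and lower numbers for stronger inhibition:
compound 1 `CCSC(=S)SCC(=O)c1ccc(NS(C)(=O)=O)cc1`: 45800 nM
compound 2 `CCSC(=S)SCC(=O)c1ccc(OC)cc1`: 1960 nM

Of these two, compound 2 has the lower number and so the stronger inhibition. Compound 3 `CCNC(=O)SCC(=O)c1ccc(OC)cc1` keeps the rest of compound 2 but changes one group: a group of 5 heavy atoms (3 carbon, 1 nitrogen, 1 oxygen; no ring) in place of a group of 5 heavy atoms (3 carbon, 2 sulfur; no ring), on a sulfur. For the measured compounds named here, the only measured step, a 23-fold lower number from compound 1 to compound 2 (1.37 log units; beyond the scatter), lies at another place on the molecule. Going by the values given here, it shows that one swap can move the number a long way in this assay, but no measured compound tests the new change, so the direction is a judgement. Among the compounds with values here, a moderate rise is expected, since compound 2 at 1960 nM is the lowest number so far. The expected step is a 4.6-fold higher number from compound 2 to compound 3 (0.66 log units; beyond the scatter), and it is uncertain. The estimated value for compound 3 is 9000 nM, with an expected range from 2500 nM to 35000 nM.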

Compound 3, half-maximal inhibitory concentration: 13300 nM
Compound 3: middle estimate off by 1.5-fold (0.17 log units), on the low side; the range from low to high includes it.
By their numbers in this assay, from the lowest: compound 2; then compound 3; then compound 1.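

Ethylcarbamoyl in place of the group of 3 carbon and 2 sulfur atoms brings a 6.8-fold higher number from compound 2 to compound 3 (0.83 log units; beyond the scatter) in this assay and so means weaker inhibition. For the compounds shown here, until now, only a change on an aromatic carbon had been tested, so this is the first sign that the group on the sulfur also matters, with the saturated chain carbon on its other side left unchanged. The two groups have the same count of 5 heavy atoms, so the number can shift markedly even when the size of the group by this count stays the same. Nothing available explains the rise in the number.

Still open, from the compounds shown here alone, is whether a propyl chain in place of the ethyl, or a carboxylic acid on this sulfur, would lower the number or raise it. Also open, going by these compounds, is whether the same swap on the sulfur would have a similar effect with methanesulfonamido in place of methoxy on the aromatic carbon.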